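A few compounds are considered here, and "the series" means these few. Any claim that something is new, unique, unknown or untested is made for them only; others in the source may bear on it.

Measured so far in an ADME assay on microsomes from liver (Rattus norvegicus) for metabolic stability, read by LC-MS, using NADPH, at 37 degrees C; a higher number here means that the compound lasts longer, a lower number that the compound disappears faster:
- compound 1 `Cc1ccccc1-c1nc(CN2CCC(C(=O)NCCCN3CCCC(C(C)C)C3)CC2)c(C)o1`: 0.323 h
- compound 2 `Cc1ccccc1-c1nc(CN2CCC(C(=O)NCCCN3CC4CCCC(C4)C3)CC2)c(C)o1`: 0.123 h

Compound 2 has the lower half-life of the pair, 0.123 h, so it disappears faster than compound 1. The next molecule, compound 3 `CCCN(CCC)CCNC(=O)C1CCN(Cc2nc(-c3ccccc3C)oc2C)CC1`, has not yet been measured. It differs from compound 2 as follows: a group of 7 heavy atoms (6 carbon, 1 nitrogen; no ring) in place of a group of 10 heavy atoms (9 carbon, 1 nitrogen; one six-membered non-aromatic ring of carbon only, one six-membered non-aromatic ring with 1 hetero atom), on a saturated chain carbon, two bonds along the chain from an amide-type nitrogen. The incoming dipropylamino group has no ring, while the group it replaces has two.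

Among the measured compounds shown here, only one measured step bears on this change: a 2.6-fold lower number from compound 1 to compound 2 (0.42 log units; beyond the scatter). There, the compound carrying the six-membered non-aromatic ring of carbon only has the lower number. This is a single comparison and not a rule, and neither measured compound shows a group without a ring, so it is a weak guide. A modest rise of about the same size is expected, with wide uncertainty: a 2.2-fold higher number from compound 2 to compound 3 (0.34 log units; beyond the scatter). For compound 3 the estimated value in this assay is 0.27 h, with an expected range from 0.1 h to 0.6 h.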

Compound 3, half-life: > 0.5 h
Compound 3: only a limit was reported; the forecaster's own chance of this, stated with the estimate: 2%; middle value at least 1.8-fold (0.26 log units) from the limit.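

In this assay, putting the ring-free dipropylamino group in place of the group with two rings, now two bonds along the chain from an amide-type nitrogen, gives an at least 4.0-fold higher number from compound 2 to compound 3 (0.60 log units; beyond the scatter). This is the first group without a ring shown here, and the step is clearly beyond the scatter, so the position tolerates an open group without compound 3 disappearing as fast as compound 2. The reading for compound 3 is a limit and not a number: the limit of > 0.5 h in this assay, at which 1 of the 3 values shown sits.

The comparison with compound 1 is weaker, at an at least 1.5-fold higher number from compound 1 to compound 3 (0.18 log units; that floor lies within the scatter), so the compounds shown separate compound 3 clearly from compound 2 but not from compound 1.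

The step to compound 3 also moves the amine from three bonds to two bonds along the chain from the amide-type nitrogen, so the compounds shown cannot tell whether the loss of the rings or the shorter chain matters more. Dipropylamino on the three-bond chain, or a piperidine on the two-bond chain, would pull these two changes apart, and how far compound 3 lies beyond its limit also stays open.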